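The source may hold more compounds than are shown below. What is called first, only, known or untested is meant among the compounds shown, and "the series" means these compounds.

Measured so far in a functional assay on Bel-7402 cells (Homo sapiens) for antiproliferative activity, read by MTT assay, with a stated time of 72 h; a lower number here means a stronger inhibitor, a higher number a weaker inhibitor:
- Compound 1 `C=C1C(=O)O[C@H]2[C@H]1CC/C(COC(=O)CCC(=O)OCn1cc(F)c(=O)[nH]c1=O)=C\CC[C@@]1(C)O[C@@H]21`: > 20000 nM, a limit.
- Compound 2 `C=C1C(=O)O[C@H]2[C@H]1CC/C(COC(=O)CCC(=O)N1CCN(C(=O)Cn3cc(F)c(=O)[nH]c3=O)CC1)=C\CC[C@@]1(C)O[C@@H]21`: > 20000 nM, a limit.
- Compound 3 `C=C1C(=O)O[C@H]2[C@H]1CC/C(COC(=O)Cn1cc(F)c(=O)n(Cc3ccc(Br)cc3)c1=O)=C\CC[C@@]1(C)O[C@@H]21`: 2670 nM.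

Going by the values given here, compound 3 is the only compound here with an actual number. Compound 1 and compound 2 share (the limit of > 20000 nM in this assay, at which 2 of the 3 values shown sit).

Compound 4 `C=C1C(=O)O[C@H]2[C@H]1CC/C(COC(=O)Cn1cc(F)c(=O)n(Cc3c(F)cccc3F)c1=O)=C\CC[C@@]1(C)O[C@@H]21` differs from compound 3 by a single change: 2,6-difluorophenyl in place of 4-bromophenyl on a saturated chain carbon bound to an aromatic nitrogen. In words, this is 2,6-difluorophenyl in place of 4-bromophenyl on a saturated chain carbon bound to an aromatic nitrogen.

Among the compounds with values here, no measured pair differs in one place, so the size of this step is a judgement only. Compound 4 stays structurally close to compound 3 at 2670 nM, so a small step toward weaker inhibition in this assay is expected, probably within the scatter. The expected step is a 1.5-fold higher number from compound 3 to compound 4 (0.18 log units; within the scatter). For compound 4 the estimate is 4000 nM, with an expected range of 1500 nM to 12000 nM.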

Compound 4, half-maximal inhibitory concentration: 4500 nM
Compound 4: middle estimate off by 1.1-fold (0.05 log units), on the low side; low and high end bracket the measured number.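

In this assay, going by these compounds alone, the only one-place comparison concerns the group on a saturated chain carbon bound to an aromatic nitrogen: exchanging 4-bromobenzyl for 2,6-difluorobenzyl gives a 1.7-fold higher number from compound 3 to compound 4 (0.23 log units; within the scatter). At this position, a single bromine and two fluorines on the phenyl ring therefore give values that cannot be told apart. Compound 4 also gives an actual number rather than a limit, which keeps this pair readable in a series where part of the data cannot be compared: the limit of > 20000 nM in this assay, at which 2 of the 4 values shown sit.

Steps to compound 1 and compound 2 cannot be read, and what the benzyl group itself contributes stays open. Also open, on these data alone, is whether a plain benzyl, a phenyl carrying an amine or a carboxylic acid, or a longer chain on that nitrogen would stay close to compound 4 at 4500 nM.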